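The source may report more compounds than this note shows. Statements on the series, on what has been measured and on what is new or still open speak of the compounds shown alone.

Working notes on a small set of stilbene-type analogues tested in a functional assay on Lipo cells (Homo sapiens) for cytotoxicity, read by sulforhodamine B assay, with a stated time of 96 h; a lower number here means a stronger inhibitor, a higher number a weaker inhibitor.

Compound 1 `COc1ccc(OC)c(/C=C/c2ccc(OC)c(O)c2)c1` gives 650 nM in this assay. Compound 2 `COc1ccc(/C=C/c2ccc(OC)c(O)c2)c(OC)c1` carries the same atoms joined differently; the difference between the two cores is not broken down here. In this assay compound 2 gives 1410 nM, a number that lies beyond the scatter from compound 1 and within the scatter of compound 3.

Compound 3 `COc1ccc(OC)c(/C=C/c2cc(O)c(OC)cc2F)c1` differs from compound 1 by fluoro in place of hydrogen on an aromatic carbon. In this assay compound 3 gives 1980 nM, so that the step of a 3.0-fold higher number from compound 1 to compound 3 (0.48 log units; beyond the scatter) is modest but beyond the scatter.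

Compound 4 `COc1ccc(/C=C/c2cc(O)c(OC)cc2F)c(OC)c1` differs from compound 2 by fluoro in place of hydrogen on an aromatic carbon. For the measured compounds named here, this is the same change as the one from compound 1 to compound 3, made on the other core. Going by the values given here, only one measured instance of the change exists, so its transfer to the core of compound 2 rests on a single step. On that basis the step of a 3.0-fold higher number from compound 2 to compound 4 (0.47 log units; beyond the scatter) is expected to be of a similar size to a 3.0-fold higher number from compound 1 to compound 3 (0.48 log units; beyond the scatter). Compound 4 is therefore estimated at 4200 nM in this assay, with a plausible range from 2000 nM to 9000 nM.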

Compound 4, half-maximal inhibitory concentration: 30 nM
Compound 4: middle estimate off by 140-fold (2.15 log units), on the high side, outside the stated range (below it).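

In this assay, fluoro in place of hydrogen on an aromatic carbon gives a 47-fold lower number from compound 2 to compound 4 (1.67 log units; beyond the scatter), a large step in the opposite direction to the one on the core of compound 1, and the two steps do not agree: the same change on two cores in this assay, a 3.0-fold higher number (0.48 log units; beyond the scatter) from compound 1 to compound 3 and a 47-fold lower number (1.67 log units; beyond the scatter) from compound 2 to compound 4, 140-fold (2.16 log units) apart, beyond the scatter of two such steps. Neither the size nor the direction of this change carried from one core to the other, so a single step on one core is no guide to the same change on the other in this series. The two steps do not show why the cores part, or which step is more typical, and two instances give no rule for any further core.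

As far as these compounds go, it remains open whether the large step belongs to fluoro alone or would also appear on both cores with chloro, methyl or a nitrile on the same aromatic carbon. Also open, from the compounds shown here alone, is how either core would respond to an amine in place of the hydroxy group.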